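The source may hold more compounds than are shown below. What is called first, only, known or untested is meant among the compounds shown, and "the series" means these compounds.

Measured in a functional assay on HCT-116 cells (Homo sapiens) for antiproliferative activity, read by sulforhodamine B assay, with a stated time of 72 h; on this read-out lower numbers stand for stronger inhibition and higher numbers for weaker inhibition:
- Compound 1 `CNC(=O)C[C@@H]1C[C@@H](c2ccc(Cl)c(Cl)c2)[C@H](NC(=O)c2cc(-c3c(Cl)cnn3C)c(Cl)o2)CN1` gives 450 nM
- Compound 2 `Cn1ncc(Cl)c1-c1cc(C(=O)N[C@@H]2CN[C@H](CCN3CCCCC3)C[C@H]2c2ccc(Cl)c(Cl)c2)oc1Cl` gives 1020 nM
- Compound 3 `Cn1ncc(Cl)c1-c1cc(C(=O)N[C@@H]2CN[C@H](CC(=O)O)C[C@H]2c2ccc(Cl)c(Cl)c2)oc1Cl` gives 4020 nM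

Compound 3 has the highest number of the three, which makes it the weakest here. Compound 4 `C=CC[C@@H]1C[C@@H](c2ccc(Cl)c(Cl)c2)[C@H](NC(=O)c2cc(-c3c(Cl)cnn3C)c(Cl)o2)CN1` has vinyl in place of carboxy on a saturated chain carbon bound to a saturated ring carbon, a change counted as vinyl in place of carboxy on a saturated chain carbon bound to a saturated ring carbon in this comparison. Two modest measured steps bear on this, an 8.9-fold higher number from compound 1 to compound 3 (0.95 log units; beyond the scatter) and a 3.9-fold higher number from compound 2 to compound 3 (0.60 log units; beyond the scatter), and both end at the carboxy compound with a rise in the number. Going by the values given here, no compound with the allyl chain has been measured, so the reverse direction is only an expectation. A similar modest step towards a lower number is therefore expected in this assay here. The estimated step is a 5.7-fold lower number from compound 3 to compound 4 (0.76 log units; beyond the scatter) overall. The expected value for compound 4 is 700 nM as a middle estimate. The estimated range for compound 4 runs from 250 nM to 2000 nM in this assay.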

Compound 4, half-maximal inhibitory concentration: 780 nM
Estimate against measurement, compound 4: 1.1-fold (0.05 log units) below; the range from low to high includes it.
By their numbers in this assay, from the lowest: compounds 1, 4 and 2 (each within the scatter of the next, the first and the last beyond it); then compound 3.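

In this assay, swapping carboxy for vinyl on a saturated chain carbon bound to a saturated ring carbon gives a 5.2-fold lower number from compound 3 to compound 4 (0.71 log units; beyond the scatter) and shows that a plain hydrocarbon end works here. Against the other two side chains, a 1.3-fold lower number from compound 2 to compound 4 (0.12 log units; within the scatter) and a 1.7-fold higher number from compound 1 to compound 4 (0.24 log units; within the scatter) both lie within the scatter. Neither the methylcarbamoyl nor the piperidinyl end is therefore needed for numbers of this size, and only the carboxy compound falls out of line.

Going by these compounds, how a primary amine or a longer carbon chain would fare at this place stays open. Nothing shown here explains the gap seen with carboxy.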